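Moving the fluorine on the benzyl group of compound 2

A few compounds are considered here, and "the series" means these few. Any claim that something is new, unique, unknown or untested is made for them only; others in the source may bear on it.

Measured compounds in a functional assay on L1210 cells (Mus musculus) for cytotoxicity, read by cell counting, with a stated time of 2 days; on this read-out higher numbers stand for weaker inhibition and lower numbers for stronger inhibition:
compound 1 `C=C(Br)C(=O)Nc1cccc(/C=C2\SC(=O)N(Cc3ccc(C)cc3)C2=O)c1` gives 600 nM
compound 2 `C=C(Br)C(=O)Nc1cccc(/C=C2\SC(=O)N(Cc3ccc(F)cc3)C2=O)c1` gives 680 nM
compound 3 `Nc1cccc(/C=C2\SC(=O)N(Cc3ccc(F)cc3)C2=O)c1` gives 142000 nM

Compound 2 stands second highest of the three numbers. Its nearest neighbour is compound 1, with a 1.1-fold higher number from compound 1 to compound 2 (0.05 log units; within the scatter); its furthest is compound 3, with a 210-fold higher number from compound 2 to compound 3 (2.32 log units; beyond the scatter). Compound 4 `C=C(Br)C(=O)Nc1cccc(/C=C2\SC(=O)N(Cc3cccc(F)c3)C2=O)c1` differs from compound 2 only in the benzyl group: 3-fluorophenyl in place of 4-fluorophenyl on a saturated chain carbon bound to an amide-type nitrogen in a ring. Within the data shown here, the one measured step that bears on this part of the shared core is the change from compound 1 to compound 2, which stayed within the scatter, so a change of fluorine position on the same ring is expected to stay within the scatter as well, with a 1.0-fold higher number from compound 2 to compound 4 (0.01 log units; within the scatter). Compound 4 is therefore estimated at 700 nM, with a range from 300 nM to 1600 nM.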

Compound 4, half-maximal inhibitory concentration: 590 nM
Beside the measured number, compound 4's estimate is 1.2-fold (0.07 log units) above it; measured number inside the range.
By their numbers in this assay, from the lowest: compounds 4, 1 and 2 (each within the scatter of the next); then compound 3.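

In this assay, the step from 4-fluorobenzyl to 3-fluorobenzyl gives a 1.2-fold lower number from compound 2 to compound 4 (0.06 log units; within the scatter), so the placement of the fluorine on this ring, and not only the choice of fluoro or methyl, leaves the number unmoved in these compounds. The change from 4-methylphenyl to 3-fluorophenyl, which alters both the group and its placement, gives a 1.0-fold lower number from compound 1 to compound 4 (0.01 log units; within the scatter). Nothing available here accounts for this lack of response.

The compounds shown leave open whether an amine or a carboxylic acid on this ring would shift the number. They also leave open whether a longer chain in place of the benzyl group would do so.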